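This account rests on a few compounds, and the source may have more. Where it says the series, first, only, none or still open, it means among the compounds named here.

Working notes on the series, read in a functional assay on HL-60 cells (Homo sapiens) for inhibition, read by CCK-8 assay, with a stated time of 48 h, tested at 20 uM; on this read-out lower numbers stand for less inhibition of growth and higher numbers for more inhibition of growth at the one concentration tested. Compound 1 (`Cc1ccc(S(=O)(=O)Oc2ccccc2/C=C(\C#N)C(=O)Nc2nnc(Cc3ccc(F)cc3)s2)cc1`) gives "not active" (no number reported), with no number reported. Compound 2 (`COc1ccc(S(=O)(=O)Oc2ccccc2/C=C(\C#N)C(=O)Nc2nnc(Cc3ccc(F)cc3)s2)cc1`) gives 100%. Compound 3 (`N#C/C(=C\c1ccccc1OS(=O)(=O)c1ccccc1[N+](=O)[O-])C(=O)Nc1nnc(Cc2ccc(F)cc2)s1`) gives 35%, the lower of the two numbers in hand, and compound 2 stands well above it. The step of a number 65 percentage points lower from compound 2 to compound 3 (beyond the scatter) is large and beyond the scatter; it is 2-nitrophenyl in place of 4-methoxyphenyl on a sulfonyl sulfur.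

Next is compound 4 (`Cc1ccc(Cc2nnc(NC(=O)/C(C#N)=C/c3ccccc3OS(=O)(=O)c3ccccc3[N+](=O)[O-])s2)cc1`), which keeps the 2-nitrophenyl group of compound 3. The change is methyl in place of fluoro on an aromatic carbon, para to a large group, so that 4-fluorobenzyl becomes 4-methylbenzyl. Among the measured compounds shown here, compound 1, compound 2 and compound 3 all carry 4-fluorobenzyl, so no measured step speaks directly to this change. For the measured compounds named here, the only numbered step lies at the sulfonyl group, elsewhere in the molecule. With no evidence at this place, no step beyond the scatter is expected in this assay, in either direction. The range stays wide because a number 65 percentage points lower from compound 2 to compound 3 (beyond the scatter) shows how far one change can move this series. The estimated step is no change at the digits printed from compound 3 to compound 4 (within the scatter). For compound 4 the estimated value is 35%, with an expected range from 10% to 70%.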

Compound 4, percent growth inhibition at one concentration: 33%
Estimate against measurement, compound 4: 2 percentage points above; low and high end bracket the measured number.
By their numbers in this assay, from the lowest: compounds 4 and 3 (each within the scatter of the next); then compound 2.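

Among the compounds shown here, with the 2-nitrophenyl group held fixed, the first measured change at this end of the molecule gives a number 2 percentage points lower from compound 3 to compound 4 (within the scatter) in this assay and so shows that 4-methylbenzyl and 4-fluorobenzyl cannot be told apart on this background. For the compounds shown here, this differs from the only earlier numbered step, at the sulfonyl group, which reads a number 65 percentage points lower from compound 2 to compound 3 (beyond the scatter) and shows that a single change can move this series far beyond the scatter. Within this one pair, fluoro and methyl on an aromatic carbon, para to a large group, therefore read alike at the one concentration tested, and no measured property is at hand to account for this. Going by these compounds alone, whether the same holds on the 4-methoxyphenyl background stays open, as the only value there is that of compound 2 at 100% and it carries 4-fluorobenzyl, so this pair says nothing about a series member with a high read-out. Also open is how an amine, a carboxylic acid or a longer chain such as butyl would read at this place, since fluoro and methyl are the only groups shown there.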